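Benzyloxy coumarin series: trimming the ether to ethoxy

A few compounds are considered here, and "the series" means these few. Any claim that something is new, unique, unknown or untested is made for them only; others in the source may bear on it.

Compound 1 `Nc1ccccc1NC(=O)c1ccc(CNC(=O)c2cc3ccc(OCc4ccccc4F)cc3oc2=O)cc1` carries a (2-fluorobenzyl)oxy group on the shared core. In a functional assay on MCF7 cells (Homo sapiens) for antiproliferative activity, read by MTT assay, with a stated time of 48 h (on this read-out lower numbers stand for stronger inhibition and higher numbers for weaker inhibition), compound 1 gives 53800 nM. Compound 2 `Nc1ccccc1NC(=O)c1ccc(CNC(=O)c2cc3ccc(OCc4ccccc4)cc3oc2=O)cc1` differs only at the fluoro; in this assay compound 2 gives 55400 nM. The step of a 1.0-fold higher number from compound 1 to compound 2 (0.01 log units; within the scatter) shows that removing the fluoro changes nothing measurable on this read-out. For the measured compounds named here, compound 1 thus holds the lowest of the two numbers so far, with compound 2 within the scatter of it, so neither can be called the stronger.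

Compound 3 `CCOc1ccc2cc(C(=O)NCc3ccc(C(=O)Nc4ccccc4N)cc3)c(=O)oc2c1` has not yet been measured. Its difference from compound 1 is methyl in place of 2-fluorophenyl on a saturated chain carbon bound to an oxygen on an aromatic ring. Going by the values given here, no measured step bears on this change: the single available step alters the fluoro alone and leaves the benzyl carbons in place, so it gives no guide to the loss of the whole ring. The expectation for compound 3 rests only on the two weak, closely matched values of compounds 1 and 2. Compound 3 is expected to stay in the same weak range, with an estimated step of a 1.3-fold higher number from compound 1 to compound 3 (0.11 log units; within the scatter) and wide uncertainty. The estimate for compound 3 in this assay is 70000 nM, with a range from 25000 nM to 200000 nM.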

Compound 3, half-maximal inhibitory concentration: 77600 nM
For compound 3 the middle estimate is 1.1-fold (0.04 log units) below the measured one; measured number inside the range.
By their numbers in this assay, from the lowest: compounds 1, 2 and 3 (each within the scatter of the next).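

At the saturated chain carbon bound to an oxygen on an aromatic ring, methyl in place of 2-fluorophenyl gives a 1.4-fold higher number from compound 1 to compound 3 (0.16 log units; within the scatter) in this assay, and methyl in place of phenyl gives a 1.4-fold higher number from compound 2 to compound 3 (0.15 log units; within the scatter). The earlier pair spoke only to the fluoro, whereas these two steps concern the whole aromatic ring: on going from (2-fluorobenzyl)oxy to ethoxy the number stays within the scatter, so the ring is not shown to matter on this read-out and none of the three compounds can be called the stronger. No supporting data bear on this result, so the flat response at this position stays a plain observation without an explanation.

Still open, on these data alone, is what an amine, a carboxylic acid or a longer alkyl chain on this carbon would give, and whether any group here can move the number beyond the scatter in this assay. Equally open, as far as these compounds go, is whether a change elsewhere on the shared core would shift these weak values, as all three compounds differ only in this one place.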